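Hydroxy in place of morpholin-4-yl on the carbonyl carbon

This account rests on a few compounds, and the source may have more. Where it says the series, first, only, none or still open, it means among the compounds named here.

Values so far in a functional assay on A549 cells (Homo sapiens) for inhibition, read by sulforhodamine B assay, with a stated time of 72 h (a higher number here means a weaker inhibitor of growth, a lower number a stronger inhibitor of growth), on the shared core:
- compound 1 `CNC(=O)/C=C/c1ccncc1-c1ccc2cc[nH]c2c1` gives 7840 nM
- compound 2 `O=C(/C=C/c1ccncc1-c1ccc2cc[nH]c2c1)N1CCOCC1` gives > 10000 nM (a limit, not a number)

For compound 2 there is no number, only the limit of > 10000 nM in this assay, at which 1 of the 2 values shown sits, in this pair. Compound 3 `O=C(O)/C=C/c1ccncc1-c1ccc2cc[nH]c2c1` carries hydroxy in place of morpholin-4-yl on a carbonyl carbon, so (morpholin-4-yl)carbonyl goes to carboxy. For the measured compounds named here, the only measured step at this carbonyl carbon is the one with morpholin-4-yl entering (an at least 1.2-fold higher number from compound 1 to compound 2 (0.10 log units; that floor lies within the scatter)), and its floor lies within the scatter. That step sets no size and no direction for the new change. No step beyond the scatter is therefore expected in this assay and both compounds are expected to stay weak. The expected step is a step that the limit leaves unreadable from compound 2 to compound 3 as an estimate only. The estimate for compound 3 is 12000 nM with an expected range of 5000 nM to 30000 nM and a report as a limit is quite possible.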

Compound 3, concentration for 50% growth inhibition: > 10000 nM
Compound 3 ended at the assay's limit; the forecaster's own chance of this, stated with the estimate: 65%; the middle value is on the limit's open side.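

In this assay, a second replacement for methylamino on the carbonyl carbon now gives an at least 1.2-fold higher number from compound 1 to compound 3 (0.10 log units; that floor lies within the scatter), so this floor, like the one for morpholin-4-yl, sets no size for the change. The steps between compound 2 and compound 3 cannot be read, and morpholin-4-yl and hydroxy cannot be ranked at this position. Compound 1 remains the only compound with a number in this assay, and both replacements for methylamino now end at the same limit: the limit of > 10000 nM in this assay, at which 2 of the 3 values shown sit.

Still open, on these data alone, is whether any group on this carbonyl carbon can give a clear step from compound 1 in either direction. Amino, or a longer chain such as ethylamino, would show whether the methylamino group can be changed with a readable result.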